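The source may hold more compounds than are shown below. What is called first, only, known or untested is meant among the compounds shown, and "the series" means these compounds.

Series notes. Among the measured compounds shown here, compound 1 `CCCCCCCCCCCCNC(=O)[C@@H](NC(=O)c1cccs1)[C@@H](C)O` gives 23900 nM in a functional assay on SiHa cells (Homo sapiens) for cytotoxicity, read by MTT assay, with a stated time of 48 h (a lower number here means a stronger inhibitor, a higher number a weaker inhibitor), the second highest of the three numbers measured so far. Compound 2 `CCCCCCCCCCCCNC(=O)[C@@H](NC(=O)c1nccc2ccccc12)[C@@H](C)O` gives 56600 nM and compound 3 `CCCCCCCCCCCCNC(=O)[C@@H](NC(=O)c1cc2ccccc2[nH]1)[C@@H](C)O` gives 21300 nM. The step of a 2.4-fold higher number from compound 1 to compound 2 (0.37 log units; beyond the scatter) is modest, a 1.1-fold lower number from compound 1 to compound 3 (0.05 log units; within the scatter) stays within the scatter, and a 2.7-fold lower number from compound 2 to compound 3 (0.42 log units; beyond the scatter) is modest. All three measured steps exchange the aromatic ring on the carbonyl carbon and keep the amide itself. Compound 4 `CCCCCCCCCCCCNC(=O)[C@@H](NS(=O)(=O)c1cccs1)[C@@H](C)O` differs from compound 1 by (thiophen-2-yl)sulfonyl in place of (thiophen-2-yl)carbonyl on an amine nitrogen. For the measured compounds named here, no measured step bears on this change; the ring is kept here and the measured steps say nothing about the carbonyl. The working expectation is a step no larger than the scatter, a 1.0-fold higher number from compound 1 to compound 4 (0.02 log units; within the scatter). Compound 4 is estimated at 25000 nM, with a range of 9000 nM to 70000 nM.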

Compound 4, half-maximal inhibitory concentration: 30900 nM
Compound 4: the middle estimate sits 1.2-fold (0.09 log units) below what was measured; the measured number falls inside the stated range.
By their numbers in this assay, from the lowest: compounds 3, 1, 4 and 2 (each within the scatter of the next, the first and the last beyond it).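

Among the compounds shown here, the (thiophen-2-yl)sulfonyl for (thiophen-2-yl)carbonyl exchange is the first change here to touch the carbonyl rather than the ring, and a 1.3-fold higher number from compound 1 to compound 4 (0.11 log units; within the scatter) is what it gives in this assay. With the ring kept, this amine nitrogen therefore tolerates sulfonyl in place of carbonyl with no step beyond the scatter, though this rests on one pair. No evidence is available to account for this result. Going by these compounds, whether the exchange carries over to the isoquinolin-1-yl and 1H-indol-2-yl rings stays open, as does the outcome with a urea or a plain methylene on that nitrogen.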